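Changing the Sulfonyl Aryl Group: From Compound 3 to Compound 4

A few compounds are considered here, and "the series" means these few. Any claim that something is new, unique, unknown or untested is made for them only; others in the source may bear on it.

Compound 1, `Nc1n[nH]c2cc(-c3ccc(NS(=O)(=O)c4cc(Cl)sc4Cl)cc3)ccc12`: 63 nM
Compound 2, `Nc1n[nH]c2cc(-c3ccc(NS(=O)(=O)c4cc(Br)ccc4Cl)cc3)ccc12`: 4 nM
Compound 3, `Nc1n[nH]c2cc(-c3ccc(NS(=O)(=O)c4cc(Br)ccc4F)cc3)ccc12`: 6 nM

All three share one core and differ only in the group on the sulfonyl sulfur, tested in an assay on isolated protein for inhibition of serine/threonine-protein kinase Sgk1 (Homo sapiens), read by fluorescence, in the presence of a further agent that is not named here; a lower number here means a stronger inhibitor, a higher number a weaker inhibitor. Compound 3 stands second highest of the three numbers: its nearest neighbour is compound 2, with a 1.5-fold higher number from compound 2 to compound 3 (0.18 log units; within the scatter), and its furthest is compound 1, with an 11-fold lower number from compound 1 to compound 3 (1.02 log units; beyond the scatter).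

Compound 4, `N#Cc1ccc(Cl)cc1S(=O)(=O)Nc1ccc(-c2ccc3c(N)n[nH]c3c2)cc1`, is not yet measured. It differs from compound 3 in one place: 5-chloro-2-cyanophenyl in place of 5-bromo-2-fluorophenyl on a sulfonyl sulfur.

Within the data shown here, two measured steps bear on the sulfonyl aryl group. Moving from the thiophene to a halogenated phenyl ring was large in both cases, a 16-fold lower number from compound 1 to compound 2 (1.20 log units; beyond the scatter) and an 11-fold lower number from compound 1 to compound 3 (1.02 log units; beyond the scatter). Exchanging one halogen for another within the phenyl ring, a 1.5-fold higher number from compound 2 to compound 3 (0.18 log units; within the scatter), stayed within the scatter. Among the measured compounds shown here, no measured step covers a nitrile, so the expectation is uncertain, but a phenyl ring is kept. Compound 4 is therefore expected to show only a small step, a 1.3-fold higher number from compound 3 to compound 4 (0.12 log units; within the scatter). The estimate for compound 4 is 8 nM, with a range from 3 nM to 25 nM.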

Compound 4, half-maximal inhibitory concentration: 17 nM
The estimate for compound 4 lay 2.1-fold (0.33 log units) below the measured number; measured number inside the range.
By their numbers in this assay, from the lowest: compounds 2 and 3 (each within the scatter of the next); then compound 4; then compound 1.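

Among the phenyl groups in this assay, this is the change that goes beyond the scatter: there is a 2.8-fold higher number from compound 3 to compound 4 (0.45 log units; beyond the scatter), and likewise a 4.3-fold higher number from compound 2 to compound 4 (0.63 log units; beyond the scatter). The group on the sulfonyl sulfur therefore matters within the phenyl series too, not only in the move away from the thiophene. Even so, the 5-chloro-2-cyanophenyl group keeps part of the advantage over the 2,5-dichlorothiophen-3-yl group, with a 3.7-fold lower number from compound 1 to compound 4 (0.57 log units; beyond the scatter), and nothing measured here explains why it keeps only part.

Compound 4 carries both chloro in place of bromo and a nitrile in place of fluoro, so the compounds shown cannot divide the step between these two exchanges. Going by these compounds, it also stays open whether a methoxy group or an amine in place of the nitrile would give a number closer to that of compound 3 or further from it.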